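Pyrazole for Isoxazole on an Aminopyrazine Amide

The compounds below may be only part of what the source reports. "The series", "measured", "known", "first", "only" and "open" are said of these compounds alone.

Measured so far:
Compound 1 `Cc1noc(C)c1-c1cnc(N)c(Oc2ccc(C(=O)Nc3ccc(Cl)cn3)cc2)n1` — 9180 nM
Compound 2 `Cc1noc(C)c1-c1cnc(N)c(Oc2ccc(C(=O)Nc3ncccc3Cl)cc2)n1` — 14800 nM

Both compounds were tested in a functional assay on LoVo cells (Homo sapiens) for inhibition, read by MTT assay, with a stated time of 72 h; on this read-out higher numbers stand for weaker inhibition and lower numbers for stronger inhibition. Going by the values given here, compound 2 holds the higher of the two numbers, but the only measured step, a 1.6-fold higher number from compound 1 to compound 2 (0.21 log units; within the scatter), exchanges one chloropyridine for another on the amide nitrogen and is small, so no order between compound 1 and compound 2 can be claimed.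

Compound 3 `Cn1cc(-c2cnc(N)c(Oc3ccc(C(=O)Nc4ncccc4Cl)cc3)n2)cn1` is the next compound and differs from compound 2 at a different place: 1-methyl-1H-pyrazol-4-yl in place of 3,5-dimethyl-1,2-oxazol-4-yl on an aromatic carbon. Among the compounds with values here, the single measured step, a 1.6-fold higher number from compound 1 to compound 2 (0.21 log units; within the scatter), concerns the chloropyridine and not the five-membered ring, so it bears on this change only indirectly, and it shows that a modest exchange of one small aromatic group for another produced no step beyond the scatter. With nothing more to go on, the expected step is a 1.2-fold lower number from compound 2 to compound 3 (0.09 log units; within the scatter), that is, no change beyond the usual scatter in either direction. Compound 3 is therefore estimated at 12000 nM in this assay, with a range from 4000 nM to 40000 nM.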

Compound 3, half-maximal inhibitory concentration: 16500 nM
For compound 3 the middle estimate is 1.4-fold (0.14 log units) below the measured one, within the range that was stated.
By their numbers in this assay, from the lowest: compounds 1, 2 and 3 (each within the scatter of the next).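

In this assay the exchange of 3,5-dimethyl-1,2-oxazol-4-yl for 1-methyl-1H-pyrazol-4-yl gives a 1.1-fold higher number from compound 2 to compound 3 (0.05 log units; within the scatter) and so stays within the scatter. Going by these compounds alone, this is the first reading at this aromatic carbon, para to an amino group, as the earlier step concerned only the chloropyridine on the amide nitrogen, and it shows that one five-membered aromatic ring with 2 hetero atoms can stand in for the other here with no step beyond the scatter. No independent measurement bears on why the number holds within the scatter across this change.

The compounds shown leave open whether this position responds at all, since both groups seen there are closely matched five-membered aromatic rings, and a plain phenyl ring, a morpholine, a carboxylic acid or a primary amine on the same carbon could show whether a step beyond the scatter is possible. They also leave open whether 1-methyl-1H-pyrazol-4-yl behaves the same way alongside the 5-chloropyridin-2-yl amide of compound 1.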